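This account rests on a few compounds, and the source may have more. Where it says the series, first, only, none or still open, it means among the compounds named here.

Working notes on the series, read in a functional assay (Nicotiana tabacum); on this read-out higher numbers stand for weaker inhibition and lower numbers for stronger inhibition. Compound 1 `CNc1nc(SC)nc2ncccc12` gives 2920 nM, compound 2 `CCCCCNc1nc(SC)nc2ncccc12` gives 650 nM, and compound 3 `CSc1nc(NC2CCC2)c2cccnc2n1` gives 720 nM. Compound 2 thus sits level with compound 3, well apart from compound 1, and the gap between the two lower values is small: a 1.1-fold higher number from compound 2 to compound 3 (0.04 log units; within the scatter).

The change now in question leads to compound 4 `CCCCC(CC)CNc1nc(SC)nc2ncccc12`: 1-ethylpentyl in place of butyl on a saturated chain carbon bound to a nitrogen on an aromatic ring. In words, 1-ethylpentyl stands in place of butyl on a saturated chain carbon bound to a nitrogen on an aromatic ring.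

Going by the values given here, three measured steps bear on this. Lengthening the chain gave a 4.5-fold lower number from compound 1 to compound 2 (0.65 log units; beyond the scatter), and the cyclobutyl replacement of methyl gave a 4.1-fold lower number from compound 1 to compound 3 (0.61 log units; beyond the scatter), both modest. Among the compounds with values here, neither shows what happens beyond the pentyl chain, and no measured compound carries a branched chain. Within the data shown here, the only comparison among larger groups is the small step from pentyl to cyclobutyl, which gives no sign of a further gain or loss with size. A step within the scatter is therefore expected in this assay, with a wide margin on either side. The estimated step is a 1.3-fold lower number from compound 2 to compound 4 (0.11 log units; within the scatter). For compound 4 the expected value is 500 nM, with an estimated range of 150 nM to 1700 nM.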

Compound 4, half-maximal inhibitory concentration: 15900 nM
For compound 4 the middle estimate is 32-fold (1.50 log units) below the measured one; measured number above the stated range.
By their numbers in this assay, from the lowest: compounds 2 and 3 (each within the scatter of the next); then compound 1; then compound 4.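

The step from the pentyl chain to the larger group reverses the earlier trend at this position: in this assay, 1-ethylpentyl in place of butyl on the saturated chain carbon gives a 24-fold higher number from compound 2 to compound 4 (1.39 log units; beyond the scatter). The loss is more than enough to cancel the earlier gain, since the same compound also stands on the far side of the small methylamino compound, with a 5.4-fold higher number from compound 1 to compound 4 (0.74 log units; beyond the scatter). The position therefore does not follow a simple rule of larger groups giving lower numbers, and compound 4 goes against the direction seen in the steps to compound 2 and compound 3, though no measured property on these compounds accounts for the change.

With only one branched chain in the set, the size of the group and the presence of the branch cannot be told apart here. A straight hexyl or octyl chain and a shorter branched group such as isobutyl would show where the numbers start to climb and whether the branch itself matters, while a chain ending in a hydroxyl or an amine would test this position in another direction.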